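Nitrone series: cyclohexyl for tert-butyl, cytotoxicity

The source may hold more compounds than are shown below. What is called first, only, known or untested is meant among the compounds shown, and "the series" means these compounds.

Working notes on two measured nitrones and one to be measured. Compound 1 `CC(C)(C)/[N+]([O-])=C/c1nsc(-c2ccccc2)n1` and compound 2 `CC(C)(C)/[N+]([O-])=C/c1nc(-c2ccccc2)ns1` share the phenyl-substituted aromatic core and the tert-butyl nitrone, differing in how that core is arranged. In an ADME assay on J774 cells (Mus musculus) for cytotoxicity, read by MTT assay, with a stated time of 48 h (on this read-out lower numbers stand for stronger inhibition and higher numbers for weaker inhibition), compound 1 gives a limit of > 400000 nM, not a number. In this assay compound 2 likewise sits at a limit, > 400000 nM, with no number inside the range tested. Compound 2 thus stands only at the top of the tested range, as the evidence the limit of > 400000 nM in this assay, at which 2 of the 2 values shown sit, states for both values shown. Compound 3 `[O-]/[N+](=C\c1nc(-c2ccccc2)ns1)C1CCCCC1` differs from compound 2 by cyclohexyl in place of tert-butyl on a double-bonded nitrogen. Within the data shown here, no step between measured compounds exists here, so the step of a number no higher from compound 2 to compound 3 (the limit leaves the size open) is expected to be none beyond the scatter, most likely another limit. For compound 3 the estimate in this assay is 400000 nM, with a range from 150000 nM to 1000000 nM.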

Compound 3, half-maximal inhibitory concentration: 100000 nM
For compound 3 the middle estimate is 4.0-fold (0.60 log units) above the measured one; the whole stated range lies above it.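

Cyclohexyl in place of tert-butyl on a double-bonded nitrogen gives an at least 4.0-fold lower number from compound 2 to compound 3 (0.60 log units; beyond the scatter) in this assay. Among these compounds, this position therefore affects the read-out, which neither earlier compound could show, and compound 3 is the first of the series with a number inside the tested range rather than a limit. The size of the step remains a lower bound, as compound 2 gives only a limit: the limit of > 400000 nM in this assay, at which 2 of the 3 values shown sit.

The compounds shown leave open whether the ring itself or simply the larger carbon substituent accounts for the step, a question that a cyclopentyl group or an unbranched hexyl chain on the same nitrogen would address. Also open, on these data alone, is whether cyclohexyl gives a similar step on the core of compound 1.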